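From methoxy to chloro: what compound 3 may show

The source may report more compounds than this note shows. Statements on the series, on what has been measured and on what is new or still open speak of the compounds shown alone.

Among the compounds with values here, in a functional assay on the whole organism with Rattus norvegicus as the target (a higher number here means that more compound is needed for the effect, a lower number that less compound is needed), compound 2 (`COc1nc(C)cc(SC)c1NC(=O)N(Cc1ccc(Oc2ccc(F)cc2)cc1)C1CCCCCC1`) stands at 1.4 mg/kg and holds the lower of the two numbers so far. Compound 1 (`COc1cc(C)nc(OC)c1NC(=O)N(Cc1ccc(Oc2ccc(F)cc2)cc1)C1CCCCCC1`) comes in at 4.5 mg/kg on the same measure. Compound 3 (`CSc1cc(C)nc(Cl)c1NC(=O)N(Cc1ccc(Oc2ccc(F)cc2)cc1)C1CCCCCC1`) keeps the methylsulfanyl group of compound 2 but carries chloro in place of methoxy on an aromatic carbon next to the ring nitrogen and ortho to a large group.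

Within the data shown here, only one measured step is at hand, and it is modest: methylsulfanyl in place of methoxy brought a 3.2-fold lower number from compound 1 to compound 2 (0.51 log units; beyond the scatter) and it replaced the other methoxy group of compound 1. Among the measured compounds shown here, no measurement yet shows what a change at the methoxy next to the ring nitrogen does, and none involves chloro. That step therefore gives little guide to direction, and a shift no larger than it is expected. The estimated outcome is a 1.3-fold higher number from compound 2 to compound 3 (0.11 log units; within the scatter) with no move beyond the scatter expected. In this assay the estimate for compound 3 is 1.8 mg/kg with 0.6 mg/kg to 5 mg/kg as the expected range.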

Compound 3, dose for half-maximal effect: 0.17 mg/kg
Beside the measured number, compound 3's estimate is 11-fold (1.02 log units) above it; the whole stated range lies above it.
By their numbers in this assay, from the lowest: compound 3; then compound 2; then compound 1.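

The position that had not yet been touched turns out to respond strongly in this assay: with methylsulfanyl held in place, chloro in place of methoxy next to the ring nitrogen gives an 8.2-fold lower number from compound 2 to compound 3 (0.92 log units; beyond the scatter) and so moves the number beyond the scatter. Within the data shown here, the earlier compounds showed only that the other methoxy group could be exchanged with gain; this result shows that the methoxy group next to the ring nitrogen can also be given up, and that a group with no hydrogen-bond acceptor count can stand there with a lower number as the outcome. Taken together, the replacements on this ring give a 26-fold lower number from compound 1 to compound 3 (1.42 log units; beyond the scatter) and the first step of large size in this short series, although nothing available bears on the reason for the drop.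

On these data alone, whether chloro brings the same step when methoxy rather than methylsulfanyl occupies the other place remains open. Also open, as far as these compounds go, is how a bromo, a methyl or an amine group would read at the position next to the ring nitrogen, and so whether the gain belongs to chloro itself or to the departure of methoxy.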